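Adding a chloro to compound 3

This account rests on a few compounds, and the source may have more. Where it says the series, first, only, none or still open, it means among the compounds named here.

Measured in an ADME assay on HEK293 cells (Homo sapiens) for cytotoxicity, with a stated time of 72 h; a lower number here means that less compound is needed, a higher number that more compound is needed for the effect:
Compound 1 `CCc1ccc(NC(=O)Nc2cc(C)nc3ccccc23)cc1`: 16000 nM
Compound 2 `Cc1cc(NC(=O)Nc2ccc(OC(F)(F)F)cc2)c2ccccc2n1`: 14000 nM
Compound 3 `Cc1cc(NC(=O)Nc2ccc(Cl)cc2)c2ccccc2n1`: > 25000 nM (a limit, not a number)

Compound 3 has no exact number in this assay. It stands at the limit of > 25000 nM in this assay, at which 1 of the 3 values shown sits.

Compound 4 `Cc1cc(NC(=O)Nc2ccc(Cl)cc2Cl)c2ccccc2n1` differs from compound 3 by one change: chloro in place of hydrogen on an aromatic carbon, ortho to a large group and meta to a chloro group (chloro in place of hydrogen on an aromatic carbon).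

Among the compounds with values here, no measured step makes this kind of change. Each one swaps one group for another, so they offer only indirect guidance. The swaps give a 1.1-fold lower number from compound 1 to compound 2 (0.06 log units; within the scatter), an at least 1.5-fold higher number from compound 1 to compound 3 (0.19 log units; that floor lies within the scatter) and an at least 1.7-fold higher number from compound 2 to compound 3 (0.25 log units; that floor lies within the scatter). None of these shows a shift beyond the scatter, which argues against expecting a large step here. Compound 1 at 16000 nM and compound 2 at 14000 nM also show that this series can give a number in this region. A small step towards a lower number is therefore the best guess, though no change beyond the scatter is just as plausible.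

This expectation corresponds to an at least 1.3-fold lower number from compound 3 to compound 4 (0.11 log units; that floor lies within the scatter).

For compound 4 the estimated value is 19000 nM, with an expected range of 9000 nM to 32000 nM.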

Compound 4, half-maximal effective concentration: 10000 nM
Compound 4: the middle estimate sits 1.9-fold (0.28 log units) above what was measured; the measured number falls inside the stated range.
By their numbers in this assay, from the lowest: compounds 4, 2 and 1 (each within the scatter of the next). At a limit, above all of these: compound 3.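

In this assay, placing a chloro on this aromatic carbon, ortho to a large group and meta to a chloro group, gives an at least 2.5-fold lower number from compound 3 to compound 4 (0.39 log units; beyond the scatter). None of the earlier steps was shown to lie beyond the scatter, and all of them swapped one group for another at a different place on this ring, so this is the first sign that filling this hydrogen position can shift the number, towards less compound being needed for the effect. The true size of the step stays unknown because compound 3 carries a limit and not a number, which makes the printed step a floor: the limit of > 25000 nM in this assay, at which 1 of the 4 values shown sits.

A single step cannot show whether any group at this position would do the same, or whether it is specific to chloro; a fluoro, a methyl, a methoxy or an amine here could each behave differently. On these data alone, it is also open whether the new chloro would have the same effect with the ethyl of compound 1 or the trifluoromethoxy of compound 2 in place of the first chloro.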